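Aryl exchange on the aromatic nitrogen: compound 3 to compound 4

The compounds below may be only part of what the source reports. "The series", "measured", "known", "first", "only" and "open" are said of these compounds alone.

Measured so far in an ADME assay on HUVEC cells (Homo sapiens) for antiproliferative activity, read by MTT assay, with a stated time of 48 h; a lower number here means a stronger inhibitor, a higher number a weaker inhibitor:
- Compound 1 `N#CC1=C(N)Oc2c(c3nc4ccccc4nc3c3ccccc23)C12C(=O)N(Cc1cnnn1-c1ccc([N+](=O)[O-])cc1)c1ccccc12`: reported only as a limit, > 50000 nM.
- Compound 2 `N#CC1=C(N)Oc2c(c3nc4ccccc4nc3c3ccccc23)C12C(=O)N(Cc1cnnn1-c1cccc(S(N)(=O)=O)c1)c1ccccc12`: 38600 nM.
- Compound 3 `N#CC1=C(N)Oc2c(N)cc3nc4ccccc4nc3c2C12C(=O)N(Cc1cnnn1-c1ccc(F)cc1)c1ccccc12`: reported only as a limit, > 50000 nM.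

Compound 3 stands at the limit of this assay, and this is where two of the three values shown sit (the limit of > 50000 nM in this assay, at which 2 of the 3 values shown sit). Compound 4 `COc1ccc(OC)c(-n2nncc2CN2C(=O)C3(C(C#N)=C(N)Oc4c(N)cc5nc6ccccc6nc5c43)c3ccccc32)c1` differs from compound 3 in one place: 2,5-dimethoxyphenyl in place of 4-fluorophenyl on an aromatic nitrogen. Going by the values given here, the only measured step of comparable kind is the aryl exchange on the same aromatic nitrogen between compound 1 and compound 2, an at least 1.2-fold lower number from compound 1 to compound 2 (0.11 log units; that floor lies within the scatter), which starts from a limit and reaches only a floor that lies within the scatter. That step gives no sign that changing the aryl group on this nitrogen moves the number beyond the scatter. For compound 4 the step of a number no higher from compound 3 to compound 4 (the limit leaves the size open) is therefore expected to be none beyond the scatter. Compound 4 is estimated at 50000 nM, with a range from 25000 nM to 100000 nM, and most likely to be reported again only as a limit.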

Compound 4, half-maximal inhibitory concentration: > 50000 nM
Compound 4 gave a limit, no number; the forecaster's own chance of this, stated with the estimate: 70%; the middle value sits exactly at the limit.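

Going by these compounds alone, compound 3 and compound 4 are both reported only as limits, so no step between them can be read. The compounds shown leave open whether any aryl group on this aromatic nitrogen moves the number beyond the scatter, and most values gather at one point: the limit of > 50000 nM in this assay, at which 3 of the 4 values shown sit.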